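The source may hold more compounds than are shown below. What is called first, only, known or untested is meant among the compounds shown, and "the series" means these compounds.

Measured compounds:
Compound 1 `N#Cc1cccc(S(=O)(=O)Oc2ccc(-c3cncn3C3CCN(C(=O)c4ccc(Cl)c(C(F)(F)F)c4)CC3)cc2)c1` — 73 nM
Compound 2 `CN(C)c1ccc(C(=O)N2CCC(n3cncc3-c3ccc(OS(=O)(=O)c4cccc(C#N)c4)cc3)CC2)cc1` — 32 nM
Compound 3 `COc1ccc(C(=O)N2CCC(n3cncc3-c3ccc(OS(=O)(=O)c4cccc(C#N)c4)cc3)CC2)cc1` — 312 nM

In an assay on HEK293 cells for antagonist activity at P2X purinoceptor 7 (Homo sapiens), read by fluorescence, with a stated time of 2 h (on this read-out higher numbers stand for weaker inhibition and lower numbers for stronger inhibition), compound 2 stands lowest of the three numbers, as the steps of a 2.3-fold lower number from compound 1 to compound 2 (0.36 log units; beyond the scatter) and a 9.8-fold higher number from compound 2 to compound 3 (0.99 log units; beyond the scatter) show. Compound 4 `CN(C)c1ccc(C(=O)N2CCC(n3cncc3-c3ccc(OS(=O)(=O)c4cccc(C(=O)NC5CC5)c4)cc3)CC2)cc1` differs from compound 2 by cyclopropylcarbamoyl in place of cyano on an aromatic carbon. Within the data shown here, none of the measured steps bears on this change: a 2.3-fold lower number from compound 1 to compound 2 (0.36 log units; beyond the scatter), a 4.3-fold higher number from compound 1 to compound 3 (0.63 log units; beyond the scatter) and a 9.8-fold higher number from compound 2 to compound 3 (0.99 log units; beyond the scatter) all alter the group on the carbonyl carbon, while the ring carrying the nitrile is untouched in every measured compound. With no guide from the data, no step beyond the scatter is expected in this assay, though the uncertainty is wide. The step of a 1.4-fold higher number from compound 2 to compound 4 (0.15 log units; within the scatter) is therefore the expectation. Compound 4 is estimated at 45 nM, within 10 nM to 220 nM.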

Compound 4, half-maximal inhibitory concentration: 0.49 nM
Estimate against measurement, compound 4: 92-fold (1.96 log units) above; the measured number lies below the stated range.
By their numbers in this assay, from the lowest: compound 4; then compound 2; then compound 1; then compound 3.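

In this assay the aromatic carbon meta to a large group, which carries the same nitrile in compound 1, compound 2 and compound 3, proves highly sensitive to substitution. Cyclopropylcarbamoyl in place of cyano gives a 65-fold lower number from compound 2 to compound 4 (1.81 log units; beyond the scatter) as a large step, whereas the earlier changes on the carbonyl carbon gave only modest ones. Nothing at hand explains this step.

From the compounds shown here alone, whether the cyclopropyl ring or the amide hydrogen matters remains open, and a primary amide, a methylamide or a carboxylic acid here would test this. Going by these compounds, whether the step carries over to the other carbonyl groups also remains open.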